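Oxazole ketone series: heteroaryl variation at the oxazole carbon

The source may report more compounds than this note shows. Statements on the series, on what has been measured and on what is new or still open speak of the compounds shown alone.

Measured so far in an assay (Rattus norvegicus) for inhibition of Fatty-acid amide hydrolase 1 (Homo sapiens); on this read-out higher numbers stand for weaker inhibition and lower numbers for stronger inhibition:
- compound 1, `NC(=O)c1cccc(-c2cnc(C(=O)CCCCCCc3ccccc3)o2)c1`, 6 nM
- compound 2, `Cc1cccnc1-c1cnc(C(=O)CCCCCCc2ccccc2)o1`, 15 nM

Compound 2 gives the highest of the two numbers recorded; its nearest neighbour is compound 1, and the step of a 2.5-fold higher number from compound 1 to compound 2 (0.40 log units; beyond the scatter) lies beyond the scatter, modest in size.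

Compound 3, `O=C(CCCCCCc1ccccc1)c1ncc(-c2ccncn2)o1`, is not yet measured. It differs from compound 2 by pyrimidin-4-yl in place of 3-methylpyridin-2-yl on an aromatic carbon.

For the measured compounds named here, only one measured step exists, and it exchanges a carbamoylphenyl for a methylpyridinyl, which is not the change made here. It does show that replacing the aromatic group at this position moves the number by a modest amount while leaving both compounds in the same region. On that basis compound 3 is expected to land near compound 2, within the span of compound 1 and compound 2, with the step of a 1.3-fold lower number from compound 2 to compound 3 (0.10 log units; within the scatter) estimated as small. The estimate for compound 3 in this assay is 12 nM, with a range of 4 nM to 40 nM.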

Compound 3, inhibition constant: 2.3 nM
Compound 3: the middle estimate sits 5.2-fold (0.72 log units) above what was measured, and the stated range ends above it.
By their numbers in this assay, from the lowest: compound 3; then compound 1; then compound 2.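

At the aromatic carbon next to the ring oxygen, pyrimidin-4-yl in place of 3-methylpyridin-2-yl gives a 6.5-fold lower number from compound 2 to compound 3 (0.81 log units; beyond the scatter) in this assay, so this position can reach lower numbers than the first two compounds suggested. The same group also improves on 3-carbamoylphenyl, with a 2.6-fold lower number from compound 1 to compound 3 (0.42 log units; beyond the scatter), which shows that a group with 0 hydrogen-bond donors can give the lowest number of the three. Nothing on hand explains either step.

On these data alone, the step from compound 2 to compound 3 removes the methyl and adds a second ring nitrogen together, and the share of each remains open. As far as these compounds go, whether unsubstituted pyridin-2-yl would stay nearer compound 2 or compound 3, and whether a methyl or an amine on the pyrimidine ring would keep the number low, also remains open.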